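A Repeated Trifluoromethoxy Swap Across Two Cores

The compounds below may be only part of what the source reports. "The series", "measured", "known", "first", "only" and "open" are said of these compounds alone.

Compound 1 `CC(O)(CSc1ccc(C(F)(F)F)cc1)C(=O)Nc1ccc(S(F)(F)(F)(F)F)cc1` and compound 2 `CC(O)(CSc1ccc(OC(F)(F)F)cc1)C(=O)Nc1ccc(S(F)(F)(F)(F)F)cc1` share one core, while compound 3 `CC(O)(COc1ccccc1C(F)(F)F)C(=O)Nc1ccc(S(F)(F)(F)(F)F)cc1` and compound 4 `CC(O)(COc1ccccc1OC(F)(F)F)C(=O)Nc1ccc(S(F)(F)(F)(F)F)cc1` share another; the difference between the two cores is not broken down here. In a functional assay on CWR22R cells (Homo sapiens) for antiproliferative activity, read by propidium iodide staining, with a stated time of 96 h (on this read-out lower numbers stand for stronger inhibition and higher numbers for weaker inhibition), compound 1 gives 14800 nM and compound 2 gives 14900 nM. The change between them, (trifluoromethoxy in place of trifluoromethyl on an aromatic carbon), produced a 1.0-fold higher number from compound 1 to compound 2 (0.00 log units; within the scatter). Compound 3 gives 1400 nM in this assay, the lowest of the three numbers and set apart from both compound 1 and compound 2 by more than the scatter. Compound 4 carries the same kind of change relative to compound 3, (trifluoromethoxy in place of trifluoromethyl on an aromatic carbon); the two instances are not the same, since here the place is ortho to a large group whereas in the earlier pair it was para to a large group. Because the measured step of a 1.0-fold higher number from compound 1 to compound 2 (0.00 log units; within the scatter) lay within the scatter, the estimated step in this assay is a 1.1-fold higher number from compound 3 to compound 4 (0.06 log units; within the scatter), with the differing surroundings of the place adding some uncertainty. Compound 4 is therefore expected to give about 1600 nM, with a likely range from 700 nM to 4000 nM.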

Compound 4, half-maximal inhibitory concentration: 7300 nM
Compound 4: the middle estimate sits 4.6-fold (0.66 log units) below what was measured; measured number above the stated range.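

In this assay the change from trifluoromethyl to trifluoromethoxy gave a 5.2-fold higher number from compound 3 to compound 4 (0.72 log units; beyond the scatter), so on this core the swap was not neutral. Set beside the earlier pair, the same change did not carry over with the same size: the same change on two cores in this assay, a 1.0-fold higher number (0.00 log units; within the scatter) from compound 1 to compound 2 and a 5.2-fold higher number (0.72 log units; beyond the scatter) from compound 3 to compound 4, 5.2-fold (0.71 log units) apart, beyond the scatter of two such steps. This shows that a step measured on one core was a poor guide to the step on the other in this series, but it does not show what sets them apart, since the two pairs differ both in their cores and in the place of the change, here ortho to a large group, and two pairs cannot separate those differences.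

The compounds shown leave open whether the change would behave alike on one core with only its place altered. They also leave open how a chlorine atom, a nitrile or a methoxy group would compare with trifluoromethyl and trifluoromethoxy at that same place.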